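A few compounds are considered here, and "the series" means these few. Any claim that something is new, unique, unknown or untested is made for them only; others in the source may bear on it.

In a functional assay on the whole organism with Mus musculus as the target, in the rotarod test (on this read-out higher numbers stand for an effect only at larger amounts of compound and lower numbers for an effect already at smaller amounts), compound 1 `CCCCCC(=O)NCC(=O)N(C)c1ccc(Cl)cc1C(=O)c1ccccc1Cl` gives 90 mg/kg and compound 2 `CCN(CC)CC(=O)NCC(=O)N(C)c1ccc(Cl)cc1C(=O)c1ccccc1Cl` gives 34 mg/kg, the lower of the two numbers. Compound 3 `CN(C(=O)CNC(=O)CN1CCN(c2ccccc2)CC1)c1ccc(Cl)cc1C(=O)c1ccccc1Cl` has 4-phenylpiperazin-1-yl in place of diethylamino on a saturated chain carbon bound to a carbonyl carbon. For the measured compounds named here, the only measured step at this place is a 2.6-fold lower number from compound 1 to compound 2 (0.42 log units; beyond the scatter), which is modest in size. Going by the values given here, no measured compound has a ring at this place, so the direction is uncertain. The expected change is small, a 1.3-fold higher number from compound 2 to compound 3 (0.12 log units; within the scatter), and is not expected to exceed the scatter. For compound 3 the estimated value is 45 mg/kg, with an expected range of 15 mg/kg to 130 mg/kg.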

Compound 3, dose for half-maximal effect: > 100 mg/kg
Compound 3 gave a limit, no number; the forecaster's own chance of this, stated with the estimate: 5%; at least 2.2-fold (0.34 log units) between middle value and limit.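

Compound 3 gives a limit and not a number: the limit of > 100 mg/kg in this assay, at which 1 of the 3 values shown sits. Placing an amine on this saturated chain carbon therefore does not by itself lower the number: the gain of a 2.6-fold lower number from compound 1 to compound 2 (0.42 log units; beyond the scatter) does not carry over to 4-phenylpiperazin-1-yl, which gives an at least 2.9-fold higher number from compound 2 to compound 3 (0.46 log units; beyond the scatter). Against the butyl compound the result is only an at least 1.1-fold higher number from compound 1 to compound 3 (0.04 log units; that floor lies within the scatter), so that comparison stays unsettled.

Still open, on these data alone, is whether a single-ring amine such as piperidine or morpholine would keep the lower number of compound 2. As far as these compounds go, how far compound 3 lies past its limit also remains unknown.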